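The source may report more compounds than this note shows. Statements on the series, on what has been measured and on what is new or still open speak of the compounds shown alone.

Working notes on the series.

Compound 1 `COc1ccc(N2CCN(C(=O)C3(C)CCc4c(C)c(O)c(C)c(C)c4O3)CC2)cc1` carries a 4-methoxyphenyl on an amine nitrogen in a ring; in a functional assay (brain) for inhibition, with Rattus norvegicus as the target (on this read-out higher numbers stand for weaker inhibition and lower numbers for stronger inhibition), compound 1 gives 700 nM. Compound 2 `Cc1c(C)c2c(c(C)c1O)CCC(C)(C(=O)N1CCNCC1)O2` differs from it by hydrogen in place of 4-methoxyphenyl on an amine nitrogen in a ring. In this assay compound 2 gives 10000 nM, so the change produced a 14-fold higher number from compound 1 to compound 2 (1.15 log units; beyond the scatter).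

Compound 3 `COc1ccc(N2CCN(CC3(C)CCc4c(C)c(O)c(C)c(C)c4O3)CC2)cc1` is built on a different core; the difference between the core of compound 3 and the core of compound 1 is not broken down here. In this assay compound 3 gives 200 nM, the lowest number among the three measured compounds, with compound 1 its nearest neighbour and compound 2 its furthest.

Compound 4 `Cc1c(C)c2c(c(C)c1O)CCC(C)(CN1CCNCC1)O2` has not yet been measured. It differs from compound 3 by hydrogen in place of 4-methoxyphenyl on an amine nitrogen in a ring, and the place of the change is worded identically for both pairs, so this is the same change as that from compound 1 to compound 2, now made on the core of compound 3. Among the compounds with values here, only one prior example of the change exists, so how far it carries over to the other core rests on that single step. On that basis a step of about a 14-fold higher number from compound 3 to compound 4 (1.15 log units; beyond the scatter) is expected in this assay, because compound 1 to compound 2 showed a 14-fold higher number from compound 1 to compound 2 (1.15 log units; beyond the scatter). Compound 4 is therefore estimated to give 2800 nM in this assay, with a plausible span from 900 nM to 9000 nM.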

Compound 4, half-maximal inhibitory concentration: 1000 nM
For compound 4 the middle estimate is 2.8-fold (0.45 log units) above the measured one; the measured number falls inside the stated range.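

Hydrogen in place of 4-methoxyphenyl on an amine nitrogen in a ring again gives a 5.0-fold higher number from compound 3 to compound 4 (0.70 log units; beyond the scatter) in this assay, so the direction of the change, towards weaker inhibition, is the same on both cores. The size of the step does not carry over, and the gap between the two steps is larger than repeated measurements would explain: the same change on two cores in this assay, a 14-fold higher number (1.15 log units; beyond the scatter) from compound 1 to compound 2 and a 5.0-fold higher number (0.70 log units; beyond the scatter) from compound 3 to compound 4, 2.9-fold (0.46 log units) apart, beyond the scatter of two such steps. With one pair on each core, this shows that the size of the step depends on the core here, but it does not show which feature of the cores sets that size, nor whether the direction would hold on any further core.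

The compounds shown leave open how much of the 4-methoxyphenyl is needed: an unsubstituted phenyl, a 4-hydroxyphenyl or a benzyl on the same ring nitrogen would separate the role of the methoxy group from that of the aromatic ring itself. A small alkyl group such as methyl on that nitrogen, made on both cores, would also show whether the gap between the two cores persists with a different group in that place.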